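Swapping the amide's tert-butyl for a trifluoroethyl group

The source may report more compounds than this note shows. Statements on the series, on what has been measured and on what is new or still open speak of the compounds shown alone.

Of the compounds shown here, two sharing one core have been measured in an ADME assay on Caco-2 cells (Homo sapiens) for permeability, in the apical to basolateral direction; a higher number here means that the compound crosses the layer faster, a lower number that the compound crosses the layer more slowly. Compound 1 `Cn1cncc1CN1CC(N(CCn2cccc2)S(=O)(=O)c2ccccn2)Cc2cc(C#N)ccc21` gives 12.4 10^-6 cm/s there, while compound 2 `Cn1cncc1CN1CC(N(CC2CCN(C(=O)C(C)(C)C)CC2)S(=O)(=O)c2ccccn2)Cc2cc(C#N)ccc21` gives 0.5 10^-6 cm/s, the lower of the two numbers; the step of a 25-fold lower number from compound 1 to compound 2 (1.39 log units; beyond the scatter) is the only one on record. Compound 3 `Cn1cncc1CN1CC(N(CC2CCN(C(=O)CC(F)(F)F)CC2)S(=O)(=O)c2ccccn2)Cc2cc(C#N)ccc21` is not yet measured. It differs from compound 2 by 2,2,2-trifluoroethyl in place of tert-butyl on a carbonyl carbon. Among the compounds with values here, no measured step touches this position: the one known step exchanges the whole group on the saturated chain carbon bound to the sulfonamide nitrogen, so it bears on the present change only loosely. With the amide's tert-butyl traded for 2,2,2-trifluoroethyl and nothing else altered, no step beyond the scatter is expected in this assay, and the estimated step of a 1.2-fold higher number from compound 2 to compound 3 (0.08 log units; within the scatter) is small. Compound 3 is therefore expected to give about 0.6 10^-6 cm/s, within a range of 0.2 10^-6 cm/s to 1.8 10^-6 cm/s.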

Compound 3, apparent permeability: 0.5 10^-6 cm/s
Beside the measured number, compound 3's estimate is 1.2-fold (0.08 log units) above it, and the stated range covers the measured number.
By their numbers in this assay, from the lowest: compounds 2 and 3 (each within the scatter of the next); then compound 1.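

Within the data shown here, this is the first reading at the carbonyl carbon itself: in this assay, 2,2,2-trifluoroethyl in place of tert-butyl gives no change at the digits printed from compound 2 to compound 3 (within the scatter). The earlier step exchanged the whole group on the saturated chain carbon, whereas this one shows that, for this pair, the number stays put when only the group on the carbonyl carbon of the amide is exchanged, and 2,2,2-trifluoroethyl, with its three fluorines, does not lift compound 3 beyond the scatter of compound 2. No supporting measurement is available to explain why the exchange leaves the number in place.

Going by these compounds, whether this holds for other groups on the same carbonyl carbon remains open, for instance a cyclopropyl ring, an amine or a carboxylic acid. On these data alone, it is also open whether a longer chain there would give a step beyond the scatter.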